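This account rests on a few compounds, and the source may have more. Where it says the series, first, only, none or still open, it means among the compounds named here.

Compound 3, `O=C(CI)NCCNc1ncnc2c1ncn2[C@@H]1O[C@H](COP(=O)(O)OP(=O)(O)OP(=O)(O)O)[C@@H](O)[C@H]1O`, was tested in an assay on isolated protein for inhibition of hexokinase-3 (Rattus norvegicus), with a stated time of 6 h, tested at 10 mM (on this read-out higher numbers stand for more inhibition at the one concentration tested (going by the name of the read-out) and lower numbers for less inhibition), and gave 0%. Compound 1, `O=C(CI)NCCCNc1ncnc2c1ncn2[C@@H]1O[C@H](COP(=O)(O)OP(=O)(O)OP(=O)(O)O)[C@@H](O)[C@H]1O`, gave 0% in this assay, and compound 2, `O=C(CI)NCCCCC(=O)NCCCCCCNc1ncnc2c1ncn2[C@@H]1O[C@H](COP(=O)(O)OP(=O)(O)OP(=O)(O)O)[C@@H](O)[C@H]1O`, gave 0%, so compound 3 sits level with both within the scatter. Going by the values given here, the one measured step that changes the chain between the ring nitrogen and the iodoacetamide, no change at the digits printed from compound 1 to compound 3 (within the scatter), shows nothing beyond the scatter. Compound 4, `O=C(CI)NCCCCCCCNc1ncnc2c1ncn2[C@@H]1O[C@H](COP(=O)(O)OP(=O)(O)OP(=O)(O)O)[C@@H](O)[C@H]1O`, carries a longer chain of the same kind: 5-(((iodomethyl)carbonyl)amino)pentyl in place of ((iodomethyl)carbonyl)amino on a saturated chain carbon, two bonds along the chain from a nitrogen on an aromatic ring. Compound 2 already shows that a much longer linker of this type still gives 0%. The step of no change at the digits printed from compound 3 to compound 4 (within the scatter) is therefore expected to stay within the scatter. Compound 4 is estimated at 0%, between 0% and 10%.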

Compound 4, a percentage reported as inhibition, at one concentration (the size of the read-out at that concentration, not a potency): 20%
Estimate against measurement, compound 4: 20 percentage points below; the whole stated range lies below it.
By their numbers in this assay, from the lowest: compounds 1, 2 and 3 (each within the scatter of the next); then compound 4.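

In this assay, going by these compounds alone, this position now shows a step beyond the scatter, which the earlier compounds did not: 5-(((iodomethyl)carbonyl)amino)pentyl in place of ((iodomethyl)carbonyl)amino gives a number 20 percentage points higher from compound 3 to compound 4 (beyond the scatter). Length alone does not account for the pattern, since the shorter chain gives a number 20 percentage points higher from compound 1 to compound 4 (beyond the scatter) and the longer chain of compound 2 gives a number 20 percentage points higher from compound 2 to compound 4 (beyond the scatter). Nothing available explains why this chain stands apart.

Still open, on these data alone, is how an unbroken alkyl chain longer than that of compound 4 would read. So is the effect of chloromethyl in place of iodomethyl on this chain.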